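Swapping an amide cap on a spiro core: two matched pairs

The compounds below may be only part of what the source reports. "The series", "measured", "known", "first", "only" and "open" are said of these compounds alone.

Of the compounds shown here, three have been tested in a functional assay on blood (Homo sapiens), with a stated time of 60 min, in the presence of a further agent that is not named here (a higher number here means that more compound is needed for the effect, a lower number that less compound is needed), and a fourth awaits its number. Compound 2 `CNC(=O)NC(=O)C1(S(=O)(=O)c2ccc(OC)c(Cl)c2)CCC2(CCNCC2)C1` carries a methylcarbamoyl group on an amide-type nitrogen. In this assay compound 2 gives only a limit, > 15000 nM, not a number. Compound 1 `COc1ccc(S(=O)(=O)C2(C(=O)Nc3ccccc3N)CCC3(CCNCC3)C2)cc1Cl` is its partner, and in this assay compound 1 gives 7500 nM. Between the two stands a single change, (2-aminophenyl in place of methylcarbamoyl on an amide-type nitrogen), and that change made an at least 2.0-fold lower number from compound 2 to compound 1 (0.30 log units; that floor lies within the scatter), a step whose floor is set because of the limit of > 15000 nM in this assay, at which 2 of the 3 values shown sit.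

Compound 3 `CCCN1CCC2(CC1)CCC(C(=O)NC(=O)NC)(S(=O)(=O)c1ccc(Oc3ccc(OC(F)(F)F)cc3)cc1)C2` shares the amide cap of compound 2 but sits on a different core; how the two cores differ is not broken down here. In this assay compound 3 gives only a limit, > 15000 nM, and no number.

Compound 4 `CCCN1CCC2(CC1)CCC(C(=O)Nc1ccccc1N)(S(=O)(=O)c1ccc(Oc3ccc(OC(F)(F)F)cc3)cc1)C2` is to compound 3 what compound 1 is to compound 2: the change is 2-aminophenyl in place of methylcarbamoyl on an amide-type nitrogen, and the place is the same in both pairs, so the two changes are the same. Carrying over the measured pair, a step of about an at least 1.8-fold lower number from compound 3 to compound 4 (0.27 log units; that floor lies within the scatter) is expected for compound 4, resting on the value of compound 1 after the same change in an at least 2.0-fold lower number from compound 2 to compound 1 (0.30 log units; that floor lies within the scatter). The estimate for compound 4 in this assay is 8000 nM, expected to fall between 2000 nM and 30000 nM, with a fair chance that the assay again reports only a limit.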

Compound 4, half-maximal effective concentration: <= 400 nM
Compound 4: no number, only a limit; the forecaster's own chance of this, stated with the estimate: 40%; middle value at least 20-fold (1.30 log units) away from the limit.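

In this assay, the same swap on the second core, 2-aminophenyl in place of methylcarbamoyl on an amide-type nitrogen, gives an at least 37-fold lower number from compound 3 to compound 4 (1.57 log units; beyond the scatter), so here the change carries over to a second core with a large step that lies clearly beyond the usual scatter. As far as these compounds go, both ends of this step are limits of the assay rather than numbers, which means the step is a floor and its true size stays unknown. What this does not show is that one core responds more strongly than the other, even though only the second step clears the scatter: the same change on two cores in this assay, an at least 2.0-fold lower number (0.30 log units; that floor lies within the scatter) from compound 2 to compound 1 and an at least 37-fold lower number (1.57 log units; beyond the scatter) from compound 3 to compound 4; the limit leaves it open whether they differ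

The two cores differ in more than one place, so these pairs cannot tell which part of the core goes with the result in compound 4, and two pairs are too few to predict the size of this change on any further core. From the compounds shown here alone, it also stays open whether the amine of the 2-aminophenyl group matters or the aromatic ring alone is enough, a question that a plain phenyl or a 2-hydroxyphenyl group on the same nitrogen would address.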